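Methyl in place of nitro: a small change on the ester

The compounds below may be only part of what the source reports. "The series", "measured", "known", "first", "only" and "open" are said of these compounds alone.

Of the compounds shown here, three have been tested in a functional assay on K562 cells (Homo sapiens) for antiproliferative activity, read by sulforhodamine B assay, with a stated time of 48 h, tested at 50 uM; a lower number here means less inhibition, a higher number more inhibition at the concentration tested (going by the name of the read-out). Compound 1 `Cc1cc2c(C(C)C)ccc(C)c2cc1OC(=O)c1cccc(C(F)(F)F)c1` is reported as "not active" (no number reported), without a number. Compound 2 `COc1ccc(C(=O)Oc2cc3c(C)ccc(C(C)C)c3cc2C)cc1` gives 88.6%. Compound 3 `CC1=CC[C@H](C(C)C)c2cc(C)c(OC(=O)c3ccc([N+](=O)[O-])cc3)cc21` gives 89%, the higher of the two numbers, though the gap to compound 2 lies within the scatter, so the two cannot be told apart.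

Compound 4 `CC1=CC[C@H](C(C)C)c2cc(C)c(OC(=O)c3ccc(C)cc3)cc21` has not yet been measured. It differs from compound 3 in one place (methyl in place of nitro on an aromatic carbon). Among the measured compounds shown here, no step between two measured compounds in this assay shows what such a change does, so any expectation must rest on the fact that compound 2 and compound 3, carrying different groups on the ester ring, gave almost the same number. On that basis the step from compound 3 to compound 4 is expected to be small and slightly downward, a number 14 percentage points lower from compound 3 to compound 4 (beyond the scatter), with no confidence that it reaches beyond the scatter. Compound 4 is therefore estimated at 75%, within a range from 40% to 95%.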

Compound 4, a percentage reported as inhibition, at one concentration (the size of the read-out at that concentration, not a potency): 100%
Estimate against measurement, compound 4: 25 percentage points below; measured number above the stated range.
By their numbers in this assay, from the lowest: compounds 2 and 3 (each within the scatter of the next); then compound 4.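

Among the compounds shown here, this is the first step that isolates one group at this place on the ester ring, para to a large group. In this assay, putting methyl in place of nitro, with its 3 heavy atoms and 2 hydrogen-bond acceptors, gives a number 11 percentage points higher from compound 3 to compound 4 (beyond the scatter), so the inhibition at this one concentration is higher for the 4-methylphenyl ester than for the 4-nitrophenyl ester. Nothing at hand explains why the step runs in this direction.

As far as these compounds go, whether an amine, a carboxylic acid or a longer chain such as propyl at this same place would keep inhibition at this level remains open. A reading at one concentration also leaves open how compound 3 and compound 4 compare in potency.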